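The source may report more compounds than this note shows. Statements on the series, on what has been measured and on what is new or still open speak of the compounds shown alone.

In a functional assay on PC-3 cells (Homo sapiens) for cytotoxicity, read by MTT assay, with a stated time of 48 h (a lower number here means a stronger inhibitor, a higher number a weaker inhibitor), the values so far are these:
- compound 1 `COc1cc(-n2c(-c3ccc(O)cc3)c[nH]c2=O)cc(OC)c1OC` gives 30200 nM as a measured number
- compound 2 `COc1ccc(-c2c[nH]c(=O)n2-c2cc(OC)c(OC)c(OC)c2)cc1OC` gives > 50000 nM as a limit
- compound 3 `COc1ccc(-c2c[nH]c(=O)n2-c2cc(OC)c(OC)c(OC)c2)cc1[N+](=O)[O-]` gives > 50000 nM as a limit

Compound 3 has no number of its own, only the limit of > 50000 nM in this assay, at which 2 of the 3 values shown sit, and so its true strength stays unread. The next compound, compound 4 `COc1ccc(-c2c[nH]c(=O)n2-c2cc(OC)c(OC)c(OC)c2)cc1N`, keeps the shared core and changes one group: amino in place of nitro on an aromatic carbon. In words, this is amino in place of nitro on an aromatic carbon, ortho to a methoxy group and meta to a large group.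

Among the measured compounds shown here, the one measured step at this place is a step that the two limits leave unreadable from compound 2 to compound 3 and it offers no size to carry over. The data therefore fix no size for the new step. For the measured compounds named here, the only readable anchor is compound 1 at 30200 nM in the same test, which shows that a number can be obtained with this core. Compound 4 may stay at the limit, as compound 2 and compound 3 did, but a move toward a stronger, readable value is expected. The expected change is an at least 2.5-fold lower number from compound 3 to compound 4 (0.39 log units; beyond the scatter) and its size is quite uncertain. For compound 4 the estimate is 20000 nM with an expected range from 1000 nM to 50000 nM as the likely span.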

Compound 4, half-maximal inhibitory concentration: 49800 nM
Compound 4: the middle estimate sits 2.5-fold (0.40 log units) below what was measured, within the range that was stated.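

In this assay, amino in place of nitro at this position gives compound 4 a measured number, 49800 nM, whereas nitro in compound 3 gave no number of its own. Among the compounds shown here, neither a number no higher from compound 2 to compound 4 (the limit leaves the size open) nor the step that starts from compound 3 can be read in size, because both steps start from a limit rather than a number: the limit of > 50000 nM in this assay, at which 2 of the 4 values shown sit. Compound 1 offers the only readable comparison, a 1.6-fold higher number from compound 1 to compound 4 (0.22 log units; within the scatter), so compound 1 and compound 4 cannot be told apart in this test, even though they differ in the aryl group, 3-amino-4-methoxyphenyl in compound 4 and 4-hydroxyphenyl in compound 1.

With a number no higher from compound 3 to compound 4 (the limit leaves the size open), the compounds shown leave open whether an acetamide or a dimethylamino group on this aromatic carbon would give a number beyond the scatter of that of the amino compound. They also leave open whether a fluorine or a chlorine in place of the methoxy group ortho to this carbon would shift the number for an amino compound in this assay.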